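The source may hold more compounds than are shown below. What is called first, only, known or untested is meant among the compounds shown, and "the series" means these compounds.

Of the compounds shown here, three sharing a core have been measured so far in an ADME assay on microsomes (Rattus norvegicus) for metabolic stability; on this read-out higher numbers stand for a longer-lived compound and lower numbers for a shorter-lived compound. Compound 1 `Cc1ccc(C2CC=NN2C(=O)C(C)(C)C)cc1F` gives 0.0433 h, compound 3 `O=C(C1CCCCC1)N1N=CCC1c1ccccc1` gives 0.0833 h, and compound 2 `O=C(C1CCN(C(=O)C(F)(F)F)CC1)N1N=CCC1c1ccccc1` gives 0.483 h. Compound 2 therefore has the highest number of the three, and its gap to each of the others lies beyond the usual scatter of repeat measurements. Compound 3 is the nearer of the two, and compound 1 is the further.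

The next compound, compound 4 `O=C(c1cocn1)N1CCC(C(=O)N2N=CCC2c2ccccc2)CC1`, is compound 2 with one piece exchanged: 1,3-oxazol-4-yl in place of trifluoromethyl on a carbonyl carbon. In words, 1,3-oxazol-4-yl takes the place of trifluoromethyl on a carbonyl carbon, so (trifluoromethyl)carbonyl becomes (1,3-oxazol-4-yl)carbonyl. For the measured compounds named here, no pair of measured compounds shows this exchange, so the data give no direct guide to its size. The best anchor is compound 2 itself, at 0.483 h, the closest relative of compound 4 among the measured compounds. The expected step of a 1.6-fold lower number from compound 2 to compound 4 (0.21 log units; within the scatter) points slightly downward but stays within the scatter, so no clear change in this assay is expected. For compound 4 the estimated half-life is 0.3 h, with an expected range of 0.1 h to 0.9 h.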

Compound 4, half-life: 0.533 h
Estimate against measurement, compound 4: 1.8-fold (0.25 log units) below; low and high end bracket the measured number.
By their numbers in this assay, from the lowest: compounds 1 and 3 (each within the scatter of the next); then compounds 2 and 4 (each within the scatter of the next).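

In this assay, placing 1,3-oxazol-4-yl on this carbonyl carbon in place of trifluoromethyl gives a 1.1-fold higher number from compound 2 to compound 4 (0.04 log units; within the scatter), so the half-life cannot be told apart between the two compounds. For the compounds shown here, this is the first step seen at this position, and it shows that a group with no ring, made of carbon and fluorine, can give way to a five-membered aromatic ring with two hetero atoms without a change beyond the usual scatter of repeat measurements. No measurement shown here explains this result.

This single step says nothing about how other groups on the same carbonyl carbon would behave, such as a simple methyl, an amine or a longer carbon chain, any of which might move the half-life away from that of compound 2 and compound 4. It also leaves open whether the exchange would have an equally small effect with a different group on the other side of the molecule, such as the fluorine-bearing and methyl-bearing aromatic ring of compound 1.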